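The source may hold more compounds than are shown below. What is called first, only, known or untested is meant among the compounds shown, and "the series" means these compounds.

Of the compounds shown here, three of a shared core have been measured in an ADME assay on microsomes from liver (Mus musculus) for metabolic stability, read by LC-MS, with a stated time of 40 min, tested at 0.5 uM; a higher number here means faster removal of the compound, a lower number slower removal. Compound 1 `O=C(Nc1cccc(S(=O)(=O)C2COC2)c1)c1cccnc1N1CCC2(CC1)CC2` gives 385 mL.min-1.g-1 in this assay. Compound 2 `COc1ccc(C(=O)Nc2cccc(S(=O)(=O)C3CCCC3)n2)c(N2CCC3(CC2)CC3)c1` reaches only the limit of this assay, recorded as > 399 mL.min-1.g-1, so no number is known for it; (the limit of > 399 mL.min-1.g-1 in this assay, at which 1 of the 3 values shown sits). Compound 3 `CC(C)(C)NS(=O)(=O)c1cccc(NC(=O)c2ccc(NS(=O)(=O)C3(C)CC3)cc2N2CCC3(CC2)CC3)c1` gives 90 mL.min-1.g-1 in this assay, the lowest of the two numbers, with compound 1 sitting a step beyond the scatter higher.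

The piece now follows the step from compound 3 to compound 4 `CC(C)(C)NS(=O)(=O)c1cccc(NC(=O)c2ccc(NS(C)(=O)=O)cc2N2CCC3(CC2)CC3)c1`, which differs in one place: methyl in place of 1-methylcyclopropyl on a sulfonyl sulfur. Among the compounds with values here, no pair of measured compounds shows this kind of change, so there is no measured step to lean on. The account therefore expects a step from compound 3 to compound 4 of a 1.2-fold lower number from compound 3 to compound 4 (0.08 log units; within the scatter), that is, no change beyond the usual scatter, if anything a slightly lower number. Compound 4 is accordingly estimated at 75 mL.min-1.g-1 in this assay, with a range from 35 mL.min-1.g-1 to 160 mL.min-1.g-1.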

Compound 4, intrinsic clearance in microsomes: 81 mL.min-1.g-1
The estimate for compound 4 lay 1.1-fold (0.03 log units) below the measured number; the measured number falls inside the stated range.
By their numbers in this assay, from the lowest: compounds 4 and 3 (each within the scatter of the next); then compound 1. At a limit, above all of these: compound 2.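

Replacing 1-methylcyclopropyl with methyl on a sulfonyl sulfur whose other neighbour is the sulfonamide nitrogen gives a 1.1-fold lower number from compound 3 to compound 4 (0.05 log units; within the scatter) in this assay and so does not separate the two groups. Within the data shown here, this is the first step between measured compounds that differ in one place, and it shows that this read-out stays within the scatter when the three-membered ring goes and the group shrinks from 4 heavy atoms to 1. No measured information given here bears on why the two groups read alike.

Going by these compounds, it remains open whether a longer chain, such as n-butyl, or a chain ending in an amine or a carboxylic acid would stay within the scatter of compound 3 at this sulfonyl sulfur. On these data alone, it also remains open whether the same exchange would read alike on a different part of the shared core.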